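Ethoxy to methoxy on a biaryl isothiocyanate series

The source may report more compounds than this note shows. Statements on the series, on what has been measured and on what is new or still open speak of the compounds shown alone.

Compound 1 `COc1ccc(-c2ccc(CO[C@H]3C[C@@H](N=C=S)C3(C)C)nc2)cc1F`: 246 nM
Compound 2 `Fc1cc(-c2cccc(OCc3ccccc3)c2)ccc1CO[C@H]1C[C@@H](N=C=S)C1`: 99.8 nM
Compound 3 `CCOc1ccc(-c2ccc(CO[C@H]3C[C@@H](N=C=S)C3)c(F)c2)cc1F`: 69.2 nM

Of the compounds shown here, three have been measured in an assay on isolated protein for inhibition of N-acylethanolamine-hydrolyzing acid amidase (Homo sapiens), read by fluorescence, with a stated time of 90 min; a higher number here means a weaker inhibitor, a lower number a stronger inhibitor. Compound 3 gives the lowest number of the three; its gap to compound 2 lies within the scatter, whereas compound 1 sits beyond the scatter above it. Within the data shown here, the compounds differ in several places at once, so no single-change step between measured compounds is available.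

Compound 4 `COc1ccc(-c2ccc(CO[C@H]3C[C@@H](N=C=S)C3)c(F)c2)cc1F` has not yet been measured. It differs from compound 3 in one place: hydrogen in place of methyl on a saturated chain carbon bound to an oxygen on an aromatic ring — ethoxy to methoxy. Among the measured compounds shown here, no measured pair isolates this change, so the expectation rests on the general observation that trimming one carbon from such a chain usually moves this kind of read-out only a little. Compound 4 is therefore expected to stay close to compound 3, with a step of a 1.4-fold higher number from compound 3 to compound 4 (0.14 log units; within the scatter) that is expected to remain within the scatter. Compound 4 is estimated at 95 nM in this assay, with a range from 40 nM to 220 nM.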

Compound 4, half-maximal inhibitory concentration: 20.6 nM
Beside the measured number, compound 4's estimate is 4.6-fold (0.66 log units) above it; the whole stated range lies above it.
By their numbers in this assay, from the lowest: compound 4; then compounds 3 and 2 (each within the scatter of the next); then compound 1.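

In this assay, among these compounds, ethoxy to methoxy gives the first single-place comparison in this set: a 3.4-fold lower number from compound 3 to compound 4 (0.53 log units; beyond the scatter). The step shows that removing the methyl on a saturated chain carbon bound to an oxygen on an aromatic ring can by itself change the read-out beyond the scatter, something compounds 1, 2 and 3 could not show, as they differ from one another in several places at once. Nothing available explains the size or direction of this step.

The compounds shown leave open how a propoxy chain or a hydroxyl group would read at this place, as the only comparison here is between ethoxy and methoxy. They also leave open whether the same change would give a step of similar size on the core of compound 1.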